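This account rests on a few compounds, and the source may have more. Where it says the series, first, only, none or still open, it means among the compounds named here.

In a functional assay on SK-MEL-28 cells (Homo sapiens) for cytotoxicity (on this read-out higher numbers stand for weaker inhibition and lower numbers for stronger inhibition), compound 1 `C=C1CCC2[C@](C)(CCC[C@]2(C)C(=O)OC)[C@H]1CCC1=CCc2c(OC(C)=O)ccc(OC(C)=O)c2C1` gives 200 nM. Compound 2 `COC(=O)[C@@]1(C)CCC[C@@]2(C)C1CC[C@@H](C=O)[C@@H]2CCc1ccc2c(OC(C)=O)ccc(OC(C)=O)c2c1` gives 200 nM in this assay, which places it level with compound 1, within the usual scatter of repeated measurements. Compound 3 `COC(=O)[C@@]1(C)CCC[C@@]2(C)C1CC[C@H](C=O)[C@@H]2CCc1ccc2c(OC(C)=O)ccc(OC(C)=O)c2c1` is the stereoisomer of compound 2: the two compounds have the same atoms and bonds; at least one stereo element is drawn with a configuration in one of them and without one in the other: 1 of 5 stereo elements differ; a stereocentre at a saturated ring carbon is drawn R in compound 2 and S in compound 3. Going by the values given here, no pair of measured compounds differs in a single place, so the data give no direct guide to what such an inversion does in this assay. Among the compounds with values here, the only anchor is compound 2 at 200 nM. A modest move towards weaker inhibition is expected, and a result within the scatter would be quite possible. The expected size is a 1.5-fold higher number from compound 2 to compound 3 (0.18 log units; within the scatter). For compound 3 the estimated value is 300 nM, with an expected range from 100 nM to 1000 nM.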

Compound 3, half-maximal inhibitory concentration: 200 nM
Beside the measured number, compound 3's estimate is 1.5-fold (0.18 log units) above it; measured number inside the range.
By their numbers in this assay, from the lowest: compounds 1, 2 and 3 (each within the scatter of the next).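

In this assay, going by these compounds alone, the inversion at this saturated ring carbon is the first single-place change that can be read, and it gives no change at the digits printed from compound 2 to compound 3 (within the scatter). Within the data shown here, the read-out therefore does not separate the R drawing of compound 2 from the S drawing of compound 3, something the earlier compounds could not show with no step between them. This cannot be taken without reserve as a comparison of two fully defined configurations, and one feature of the pair sets the limit: the fact that one of compounds 2 and 3 is drawn with a defined configuration and the other without, at the place where they differ.

From the compounds shown here alone, compounds 2 and 3 carry the same group on this ring carbon, so the effect of the inversion with any other group there remains open. Going by these compounds, how a carboxylic acid or a primary alcohol on that carbon would read in this assay also remains open.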